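The source may report more compounds than this note shows. Statements on the series, on what has been measured and on what is new or still open speak of the compounds shown alone.

Measured compounds in a functional assay on HepG2 cells (Homo sapiens) for inhibition, read by sulforhodamine B assay, with a stated time of 24 h; on this read-out lower numbers stand for stronger inhibition and higher numbers for weaker inhibition:
- compound 1, `N#Cc1c(-c2ccccc2)cn(-c2ccc(S(=O)(=O)Nc3ccccn3)cc2)c1N`: 5300 nM
- compound 2, `N#Cc1c(-c2ccccc2)cn(-c2ccc(S(=O)(=O)Nc3ccccn3)cc2)c1NC(N)=O`: 4120 nM
- compound 3, `N#Cc1c(-c2ccccc2)cn(-c2ccc(S(=O)(=O)Nc3nccs3)cc2)c1N1C(=O)CCC1=O`: 4560 nM

On the numbers alone compound 3 stands second highest of the three, with compound 2 nearest and compound 1 furthest; both gaps lie within the scatter, so the three compounds are not separated by this assay.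

Compound 4, `N#Cc1c(-c2ccccc2)cn(-c2ccc(S(=O)(=O)Nc3ccccn3)cc2)c1N1C(=O)CCC1=O`, is the next compound to be measured. It differs from compound 3 by pyridin-2-yl in place of 1,3-thiazol-2-yl on a sulfonamide nitrogen. Among the measured compounds shown here, the single measured step, a 1.3-fold lower number from compound 1 to compound 2 (0.11 log units; within the scatter), concerns a different place on the shared core, the amine nitrogen rather than the sulfonamide nitrogen, and it stays within the scatter. For the measured compounds named here, no measured pair shows the exchange of the thiazolyl group for the pyridyl group on the sulfonamide nitrogen, so no step bears on it directly. What the series does show is that three variations at the amine nitrogen, combined with either ring on the sulfonamide, all return numbers within the scatter of one another.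

On that basis no step beyond the scatter is expected for compound 4 in this assay, with a 1.0-fold lower number from compound 3 to compound 4 (0.01 log units; within the scatter) as the expected step. Compound 4 is estimated at 4500 nM, with a range of 2000 nM to 10000 nM.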

Compound 4, half-maximal inhibitory concentration: 5360 nM
Estimate against measurement, compound 4: 1.2-fold (0.08 log units) below; the range from low to high includes it.
By their numbers in this assay, from the lowest: compounds 2, 3, 1 and 4 (each within the scatter of the next).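

In this assay, the exchange of 1,3-thiazol-2-yl for pyridin-2-yl on the sulfonamide nitrogen can now be read directly as a single change, and a 1.2-fold higher number from compound 3 to compound 4 (0.07 log units; within the scatter) does not separate the two rings, at least with 2,5-dioxopyrrolidin-1-yl held constant on the shared core. With pyridin-2-yl held constant instead, the other position now has a complete set of single changes: 2,5-dioxopyrrolidin-1-yl in place of ureido gives a 1.3-fold higher number from compound 2 to compound 4 (0.11 log units; within the scatter), and 2,5-dioxopyrrolidin-1-yl in place of amino gives a 1.0-fold higher number from compound 1 to compound 4 (0.00 log units; within the scatter), so neither exchange separates the compounds in this assay. No supporting data are available to explain this lack of separation at either position.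

Open, as far as these compounds go, is whether a group of another kind on the sulfonamide nitrogen, such as a methyl group or a chain ending in a carboxylic acid, would give a step beyond the scatter. Also open, from the compounds shown here alone, is whether the ring exchange reads the same with amino or ureido in place of 2,5-dioxopyrrolidin-1-yl, and whether a substituent such as chloro on the phenyl group of the shared core would move the number in this assay.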